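The compounds below may be only part of what the source reports. "The series", "measured", "known", "first", "only" and "open" are said of these compounds alone.

Measured compounds:
Compound 1 `CC(C)c1ccc(-c2nc(CN3CCN(c4ccnc5cc(Cl)ccc45)CC3)no2)cc1`; in an ADME assay on the whole organism (Mus musculus, strain BALB/c) for pharmacokinetics, at a dose of 30 mg/kg by the oral route (a lower number here means less compound in the circulation, a higher number more compound in the circulation at the dose given), compound 1 gives 5590 nM.
Compound 2 `CC(C)c1ccc(-c2nc(CN3CCN(c4ccnc5cc(-c6cccnc6)ccc45)CC3)no2)cc1`; in this assay compound 2 gives 15200 nM.

Compound 2 stands highest of the two numbers in this assay, with the step of a 2.7-fold higher number from compound 1 to compound 2 (0.43 log units; beyond the scatter) separating it from compound 1. Compound 3 `Cc1cccc(-c2nc(CN3CCN(c4ccnc5cc(-c6cccnc6)ccc45)CC3)no2)c1C` has not yet been measured in this assay. Its change from compound 2 is 2,3-dimethylphenyl in place of 4-isopropylphenyl on an aromatic carbon. Among the compounds with values here, the only measured step, a 2.7-fold higher number from compound 1 to compound 2 (0.43 log units; beyond the scatter), concerns a different part of the shared core, so no measured step bears directly on this change. With nothing in the data to anchor the direction, the expectation for this assay is a step not clearly beyond the scatter, either way. Compound 3 is therefore estimated at 13000 nM in this assay, within a range from 4500 nM to 38000 nM, which corresponds to an expected step of a 1.2-fold lower number from compound 2 to compound 3 (0.07 log units; within the scatter).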

Compound 3, maximal plasma concentration: 13400 nM
For compound 3 the middle estimate is 1.0-fold (0.01 log units) below the measured one; the measured number falls inside the stated range.
By their numbers in this assay, from the lowest: compound 1; then compounds 3 and 2 (each within the scatter of the next).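

Replacing 4-isopropylphenyl with 2,3-dimethylphenyl, on the aromatic carbon of the five-membered ring with 2 nitrogen and 1 oxygen, gives a 1.1-fold lower number from compound 2 to compound 3 (0.05 log units; within the scatter) in this assay. Within the data shown here, the earlier step concerned another part of the shared core, so this is the first reading at this position, and here two differently substituted carbon-only phenyl groups give numbers within the scatter of each other. No accompanying measurement accounts for this result.

Going by these compounds, one pair of carbon-only aromatic groups says little about the position as a whole, and it remains open whether a phenyl ring carrying an amine or a carboxylic acid would stay as close to compound 2. On these data alone, it is also open whether chloro in place of pyridin-3-yl would give a similar step alongside 2,3-dimethylphenyl.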